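A few compounds are considered here, and "the series" means these few. Any claim that something is new, unique, unknown or untested is made for them only; others in the source may bear on it.

Compound 1 `CCCOC(=O)Nc1ccc([Se]C#N)cc1` gives 28400 nM in a functional assay on HT-29 cells (Homo sapiens) for cytotoxicity, read by MTT assay, with a stated time of 72 h; a lower number here means a stronger inhibitor of growth, a higher number a weaker inhibitor of growth. Compound 2 `CCCCOC(=O)Nc1ccc([Se]C#N)cc1` gives 8100 nM in this assay, and compound 3 `C=CCOC(=O)Nc1ccc([Se]C#N)cc1` gives 24500 nM. Among these three numbers compound 3 stands second highest: its nearest neighbour is compound 1, and the step of a 1.2-fold lower number from compound 1 to compound 3 (0.06 log units; within the scatter) lies within the scatter, whereas the step of a 3.0-fold higher number from compound 2 to compound 3 (0.48 log units; beyond the scatter) lies beyond it. Compound 4 `CCOC(=O)Nc1ccc([Se]C#N)cc1` has not yet been measured in this assay. The change from compound 3 to compound 4 is methyl in place of vinyl on a saturated chain carbon bound to an oxygen next to a carbonyl group. For the measured compounds named here, two measured steps bear on this change. The step of a 1.2-fold lower number from compound 1 to compound 3 (0.06 log units; within the scatter) shows that exchanging vinyl for ethyl at this position moves the number only within the scatter. The step of a 3.5-fold lower number from compound 1 to compound 2 (0.54 log units; beyond the scatter), methyl in place of hydrogen three bonds along the chain from an oxygen next to a carbonyl group, lowers the number modestly; the present change shortens the chain instead, so any movement is expected to run the other way, toward a higher number, and to be small. Compound 4 is therefore expected to show only a small step, a 1.3-fold higher number from compound 3 to compound 4 (0.12 log units; within the scatter). The estimate for compound 4 is 32000 nM, with a likely range from 13000 nM to 80000 nM.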

Compound 4, concentration for 50% growth inhibition: 9300 nM
Beside the measured number, compound 4's estimate is 3.4-fold (0.54 log units) above it; the measured number lies below the stated range.
By their numbers in this assay, from the lowest: compounds 2 and 4 (each within the scatter of the next); then compounds 3 and 1 (each within the scatter of the next).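

Exchanging allyl for ethyl in this assay turns out not to be a silent change, since a 2.6-fold lower number from compound 3 to compound 4 (0.42 log units; beyond the scatter) shows a real shift at the position where the earlier swap of vinyl for ethyl, a 1.2-fold lower number from compound 1 to compound 3 (0.06 log units; within the scatter), moved nothing beyond the scatter. Shortening the chain of compound 1 from propyl to ethyl gives a 3.1-fold lower number from compound 1 to compound 4 (0.48 log units; beyond the scatter) and lengthening it gives a 3.5-fold lower number from compound 1 to compound 2 (0.54 log units; beyond the scatter), so both changes lower the number and chain length here does not push it steadily in one direction. The two chains on either side of propyl also land together, as a 1.1-fold higher number from compound 2 to compound 4 (0.06 log units; within the scatter) shows, which places compound 1 and compound 3 in a higher pair and compound 2 and compound 4 in a lower pair with no simple trend in size across the four.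

Nothing measured here explains why the four compounds fall into these two pairs. From the compounds shown here alone, it also stays open whether a longer chain, a phenyl ring or an amine carried on this chain would lower the number further or raise it.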